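This account rests on a few compounds, and the source may have more. Where it says the series, first, only, none or still open, it means among the compounds named here.

Series notes. Compound 1 `CCCCCCNc1nc(NCCCCCC)c2ccccc2n1` and compound 2 `Cc1ccc(CNc2nc(NCc3ccc(C)cc3)c3ccccc3n2)cc1` share one core; compound 3 `CCNc1nc(SCC)nc2ncccc12` is built on another. In a functional assay on HT-29 cells (Homo sapiens) for cytotoxicity, read by neutral red uptake, with a stated time of 72 h (on this read-out higher numbers stand for weaker inhibition and lower numbers for stronger inhibition), compound 1 gives 5810 nM. Compound 2 gives 4420 nM in this assay. Compound 3 gives 26200 nM in this assay, the highest of the three numbers; its gaps to compound 1 and to compound 2 both lie beyond the scatter, so compound 3 is the weakest inhibitor measured so far. Compound 4 `CCCCCCNc1nc(SCC)nc2ncccc12` keeps the core of compound 3 and changes one place: butyl in place of hydrogen on a saturated chain carbon, two bonds along the chain from a nitrogen on an aromatic ring. Among the measured compounds shown here, no step between measured compounds covers such a chain extension. Compound 1, which carries hexyl chains on its own core, gives 5810 nM, a lower number than compound 3, which supports at most a modest move downward. The step from compound 3 to compound 4 is expected to be a 2.0-fold lower number from compound 3 to compound 4 (0.30 log units; within the scatter), near the edge of the scatter. Compound 4 is estimated at 13000 nM, with a range from 4500 nM to 38000 nM.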

Compound 4, half-maximal inhibitory concentration: 22500 nM
Estimate against measurement, compound 4: 1.7-fold (0.24 log units) below; the range from low to high includes it.
By their numbers in this assay, from the lowest: compounds 2 and 1 (each within the scatter of the next); then compounds 4 and 3 (each within the scatter of the next).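

In this assay, butyl in place of hydrogen on this saturated chain carbon gives a 1.2-fold lower number from compound 3 to compound 4 (0.07 log units; within the scatter) and so, on the core of compound 3, the change from ethyl to hexyl does not separate the two compounds. This position therefore takes four more chain carbons with no readable shift in cytotoxicity. Nothing at hand accounts for this flat step.

Still open, going by these compounds, is whether a longer chain than hexyl, or a chain ending in an amine or a carboxylic acid, would move the number here. A single step also cannot show whether chains of intermediate length, such as propyl, behave the same way.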